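This account rests on a few compounds, and the source may have more. Where it says the series, first, only, none or still open, it means among the compounds named here.

In a functional assay on MDA-MB-231 cells (Homo sapiens) for inhibition, read by colorimetric assay and sulforhodamine B assay, with a stated time of 48 h (on this read-out lower numbers stand for stronger inhibition of growth and higher numbers for weaker inhibition of growth), compound 1 (`CCCCCCCCCCCC[C@@H](O)[C@H]1CC[C@H]([C@H](O)CCCCCCCCCCNC(=O)c2ccco2)O1`) gives 100000 nM. Compound 2 (`CCCCCCCCCCCC[C@@H](O)[C@H]1CC[C@H]([C@H](O)CCCCCCCCCCNC(=O)c2ccoc2)O1`) gives 100000 nM. Compound 3 (`CCCCCCCCCCCC[C@@H](O)[C@H]1CC[C@H]([C@H](O)CCCCCCCCCCNC(=O)c2cncs2)O1`) gives 100000 nM, which places it level with the other two at the digits shown.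

Compound 4 (`CCCCCCCCCCCC[C@@H](O)[C@H]1CC[C@H]([C@H](O)CCCCCCCCCCNC(=O)c2ccnn2C)O1`) keeps the shared core and has 1-methyl-1H-pyrazol-5-yl in place of 1,3-thiazol-5-yl on a carbonyl carbon.

For the measured compounds named here, three measured steps bear on this change, as each swaps one five-membered aromatic ring on that same carbonyl carbon for another. They read no change at the digits printed from compound 1 to compound 2 (within the scatter), no change at the digits printed from compound 1 to compound 3 (within the scatter) and no change at the digits printed from compound 2 to compound 3 (within the scatter). Going by the values given here, no compound carrying 1-methyl-1H-pyrazol-5-yl has been measured, so the expectation rests on these three steps alone. With compound 3 at 100000 nM and none of the three swaps moving the value, no shift beyond the scatter is expected in this assay, and the expected result is no change at the digits printed from compound 3 to compound 4 (within the scatter). The estimated value for compound 4 is 100000 nM, with an expected range from 40000 nM to 150000 nM.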

Compound 4, concentration for 50% growth inhibition: 8510 nM
Compound 4: the middle estimate sits 12-fold (1.07 log units) above what was measured; the measured number lies below the stated range.
By their numbers in this assay, from the lowest: compound 4; then compounds 1, 2 and 3 (each within the scatter of the next).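

In this assay, the position on the carbonyl carbon does respond to a change of ring: the read-out shows a 12-fold lower number from compound 3 to compound 4 (1.07 log units; beyond the scatter), together with a 12-fold lower number from compound 2 to compound 4 (1.07 log units; beyond the scatter) and a 12-fold lower number from compound 1 to compound 4 (1.07 log units; beyond the scatter). The three earlier swaps had moved nothing, so the ring here is not interchangeable, and 1-methyl-1H-pyrazol-5-yl stands apart even though, like 1,3-thiazol-5-yl, it is one five-membered aromatic ring with 2 hetero atoms and the same counts of donors and acceptors. No available evidence bears on what lies behind this step.

The compounds shown leave open whether the methyl group or the pyrazole ring carries the step. They also leave open how a 1H-pyrazol-5-yl without that methyl, a 1-ethyl-1H-pyrazol-5-yl or a phenyl on the same carbonyl carbon would read.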